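From ethynyl to propargyl at the assay limit

A few compounds are considered here, and "the series" means these few. Any claim that something is new, unique, unknown or untested is made for them only; others in the source may bear on it.

In a functional assay on Vero cells (Chlorocebus sabaeus) for cytotoxicity (on this read-out lower numbers stand for higher toxicity in this test and higher numbers for lower toxicity in this test), compound 1 (`O=c1ccn(CC2(CO)CC2CO)c(=O)[nH]1`) gives > 500 ug/mL, which is a limit. Compound 2 (`C#Cc1cn(CC2(CO)CC2CO)c(=O)[nH]c1=O`) gives > 500 ug/mL, also a limit. Going by the values given here, the only measured step is a step that the two limits leave unreadable from compound 1 to compound 2, so it offers no size to carry forward. Compound 3 (`C#CCc1cn(CC2(CO)CC2CO)c(=O)[nH]c1=O`) has propargyl in place of ethynyl on an aromatic carbon. Among the compounds with values here, with the limit of > 500 ug/mL in this assay, at which 2 of the 2 values shown sit, as the only guide, no change beyond the usual scatter is expected in this assay. The estimated step is a number no higher from compound 2 to compound 3 (the limit leaves the size open). The estimate for compound 3 is 500 ug/mL, with a range of 250 ug/mL to 1000 ug/mL.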

Compound 3, half-maximal cytotoxic concentration: > 500 ug/mL
Compound 3: a limit, no number (the forecaster's own chance of this, stated with the estimate: 85%); the middle value sits exactly at the limit.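

In this assay, going by these compounds alone, compound 1, compound 2 and compound 3 each give only a limit, and no step among them can be read. The compounds shown leave open whether any change on the shared core would give a readable number.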